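A few compounds are considered here, and "the series" means these few. Any claim that something is new, unique, unknown or untested is made for them only; others in the source may bear on it.

Three analogues of the shared sulfonamide series have numbers in an assay on isolated protein for inhibition of alkaline phosphatase, tissue-nonspecific isozyme (Homo sapiens); on this read-out lower numbers stand for stronger inhibition and higher numbers for weaker inhibition. Compound 1, `COc1ccc(C#N)cc1S(=O)(=O)Nc1cnc2ccccc2c1`, gives 38 nM. Compound 2, `COC(=O)c1cncc(NS(=O)(=O)c2cc(Cl)ccc2OC)c1`, gives 65 nM, the highest number of the three; compound 1 sits within the scatter of it, while compound 3 lies beyond the scatter on the lower side. Compound 3, `COc1ccc(F)cc1S(=O)(=O)Nc1cncc(C(N)=O)c1`, gives 19 nM.

Compound 4, `CNC(=O)c1cncc(NS(=O)(=O)c2cc(Cl)ccc2OC)c1`, is not yet measured. It differs from compound 2 by a single change: methylamino in place of methoxy on a carbonyl carbon. Among the compounds with values here, no measured pair isolates this exchange, so the expectation rests only on the three numbers above. The step from compound 2 to compound 4 in this assay is expected to be modest and toward a lower number, a 1.6-fold lower number from compound 2 to compound 4 (0.21 log units; within the scatter), with a real chance of no change beyond the scatter. Compound 4 is accordingly estimated at 40 nM, within a range of 15 nM to 120 nM.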

Compound 4, half-maximal inhibitory concentration: 109 nM
Compound 4: the middle estimate sits 2.7-fold (0.44 log units) below what was measured, and the stated range covers the measured number.
By their numbers in this assay, from the lowest: compounds 3, 1, 2 and 4 (each within the scatter of the next, the first and the last beyond it).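

In this assay, the first pair isolating this change gives a 1.7-fold higher number from compound 2 to compound 4 (0.22 log units; within the scatter) for methylamino in place of methoxy on a carbonyl carbon. At this place, then, the exchange of an oxygen-linked for a nitrogen-linked methyl, with the counted acceptor giving way to a donor, does not separate the two compounds beyond the scatter. No supporting measurement offers any explanation of this result.

Still open, going by these compounds, is whether a carboxylic acid, a dimethylamino group or an ethylamino group on this carbonyl carbon would stay within the scatter of compound 2. Also open, on these data alone, is whether methylamino for methoxy reads the same with a different group in place of the chlorine.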